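Methyl to Propyl on the Ring Amide Nitrogen

The compounds below may be only part of what the source reports. "The series", "measured", "known", "first", "only" and "open" are said of these compounds alone.

Compound 1, `COc1cccc(OS(=O)(=O)c2ccc(N3CCN(C)C3=O)cc2)c1`: 3000 nM in a functional assay on MCF7 cells (Homo sapiens) for antiproliferative activity, read by sulforhodamine B assay, with a stated time of 48 h; on this read-out lower numbers stand for stronger inhibition and higher numbers for weaker inhibition.
Compound 2, `Cc1ccc(OS(=O)(=O)c2ccc(N3CCN(C)C3=O)cc2)cc1`: only a limit, > 100000 nM, in this assay.

Among the compounds with values here, compound 1 carries the only actual number in this assay; the one other value shown is a limit rather than a number. Within the data shown here, the single measured step, an at least 33-fold higher number from compound 1 to compound 2 (1.52 log units; beyond the scatter), comes from exchanging the aryl ring on the oxygen, 4-methylphenyl in place of 3-methoxyphenyl, and it ends at the limit of > 100000 nM in this assay, at which 1 of the 2 values shown sits, so its true size is known only as a lower bound.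

Compound 3, `CCCN1CCN(c2ccc(S(=O)(=O)Oc3cccc(OC)c3)cc2)C1=O`, differs from compound 1 by ethyl in place of hydrogen on a saturated chain carbon bound to an amide-type nitrogen in a ring. The measured step between compound 1 and compound 2 lies on the other side of the shared core and says nothing about a change on the amide-type nitrogen in the ring. Among the measured compounds shown here, no measured step bears on this change. With nothing to point either way, the expectation for compound 3 is a step of no change at the digits printed from compound 1 to compound 3 (within the scatter), that is, nothing beyond the usual scatter. Compound 3 is therefore estimated at 3000 nM, with a plausible span from 1000 nM to 10000 nM.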

Compound 3, half-maximal inhibitory concentration: 6300 nM
Compound 3: the middle estimate sits 2.1-fold (0.32 log units) below what was measured; low and high end bracket the measured number.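

Within the data shown here, exchanging the methyl of compound 1 for the propyl of compound 3 gives a 2.1-fold higher number from compound 1 to compound 3 (0.32 log units; beyond the scatter) in this assay, the first measured step at this position, and it is modest. Unlike the exchange of the aryl ring on the oxygen, this change on the ring amide nitrogen leaves an actual number rather than a limit, so the 2-oxo-3-propylimidazolidin-1-yl compound keeps measurable antiproliferative activity. Nothing measured here accounts for the direction or the size of this step, and the one available note concerns only the limit reached by compound 2.

With only methyl and propyl shown on this nitrogen, it remains open whether a longer chain, a cyclopropyl group, or a chain ending in an amine or a carboxylic acid would continue this modest rise in the number, leave it unchanged or reverse it. From the compounds shown here alone, it also remains open whether propyl would give a similar step with 4-methylphenyl on the oxygen, as it appears here only with 3-methoxyphenyl.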